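The compounds below may be only part of what the source reports. "The series", "measured", "known", "first", "only" and "open" are said of these compounds alone.

Compound 1 `O=C(NCc1ccc(-c2ccccc2)cc1)c1cccc(=O)n1O` gives 25000 nM in an assay on isolated protein for inhibition of matrix metalloproteinase-9 (Homo sapiens); a higher number here means a weaker inhibitor, a lower number a stronger inhibitor.
Compound 2 `O=C(NCc1ccc(-c2ccccc2)cc1)c1occc(=O)c1O` gives 25000 nM in this assay.
Compound 3 `Cn1ccc(=O)c(O)c1C(=O)NCc1ccc(-c2ccccc2)cc1` gives 25000 nM in this assay.

Compound 3 stands level with compound 1 and compound 2 at the digits printed; the three values lie within the scatter of one another, so no order among them can be read. Going by the values given here, the one step that has been measured, no change at the digits printed from compound 1 to compound 2 (within the scatter), exchanged the whole ring that carries the amide and left the result unchanged within the scatter.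

Compound 4 `Cc1cc(=O)c(O)c(C(=O)NCc2ccc(-c3ccccc3)cc2)n1C` is obtained from compound 3 by methyl in place of hydrogen on an aromatic carbon. Among the compounds with values here, no measured step alters this ring position, so the only guide is the step from compound 1 to compound 2, which changed the same core far more drastically and still moved nothing beyond the scatter. On that basis a methyl added to the core is expected to leave this assay where it stands, with no step beyond the scatter, so the expected step of no change at the digits printed from compound 3 to compound 4 (within the scatter) is essentially flat.

Compound 4 is therefore estimated at 25000 nM, with a range from 10000 nM to 60000 nM.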

Compound 4, half-maximal inhibitory concentration: 25000 nM
Estimate against measurement, compound 4: no gap at the digits printed; the measured number falls inside the stated range.
By their numbers in this assay, from the lowest: compounds 1, 2, 3 and 4 (each within the scatter of the next).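

Methyl in place of hydrogen on an aromatic carbon, next to the ring nitrogen and para to a hydroxy group, gives no change at the digits printed from compound 3 to compound 4 (within the scatter) in this assay. This is the first step shown at this position, and it adds a single carbon to the core, whereas the earlier step exchanged the whole ring that carries the amide; at this position, at least, the methyl leaves compound 4 level with compound 3. No measurement offered here accounts for this flat result.

The compounds shown leave open whether a different group at this position, such as an amine, a carboxylic acid or a longer chain, would give a value apart from that of compound 4, and what a change to the group on the amide nitrogen, which all four compounds share, would do. All four values lie within the scatter of one another, so the series holds no step beyond the scatter and does not show which part of these compounds, if any, can move the number in this assay.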